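The source may report more compounds than this note shows. Statements on the series, on what has been measured and on what is new or still open speak of the compounds shown alone.

Among the measured compounds shown here, compound 1, with the structure `c1cc(-c2cnc3cc4c(cc3n2)C2CNCC4C2)c[nH]1`, is the weaker of the two compounds measured so far. In an assay for binding affinity to Neuronal acetylcholine receptor; alpha4/beta2 (Rattus norvegicus) (a higher number here means a weaker inhibitor, a lower number a stronger inhibitor), compound 1 gives 360 nM. The other measured compound, compound 2, has the structure `CC(C)c1nc2cc3c(cc2o1)C1CNCC3C1`; in this assay compound 2 gives 7.6 nM, a much lower number, but compound 2 differs from compound 1 in more than one place, so the two values say nothing about any single change.

Compound 3, with the structure `COc1ccc(-c2cnc3cc4c(cc3n2)C2CNCC4C2)cc1`, has not yet been measured. It differs from compound 1 in one place: 4-methoxyphenyl in place of 1H-pyrrol-3-yl on an aromatic carbon. For the measured compounds named here, nothing measured so far shows what this exchange does in this assay, since no pair of measured compounds differs by it alone.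

Going by the values given here, with no measured step to lean on, the expectation for compound 3 rests only on the value of compound 1, 360 nM, and on the size of the change. The step from compound 1 to compound 3 is expected to be a 2.5-fold higher number from compound 1 to compound 3 (0.40 log units; beyond the scatter), a modest move towards a weaker inhibitor. For compound 3 the estimated value in this assay is 900 nM, with a range from 250 nM to 3500 nM.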

Compound 3, inhibition constant: 26 nM
Compound 3: middle estimate off by 35-fold (1.54 log units), on the high side, outside the stated range (below it).
By their numbers in this assay, from the lowest: compound 2; then compound 3; then compound 1.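

The exchange at this aromatic carbon, next to the ring nitrogen, is a large one: in this assay it gives a 14-fold lower number from compound 1 to compound 3 (1.14 log units; beyond the scatter), a step well beyond the usual scatter. Among the compounds shown here, this pair shows that the position is far from indifferent to what it carries, since the core stays the same and only this one group differs. It also shows that this place accepts a group with more heavy atoms and no hydrogen-bond donor, and that the hydrogen-bond donor of 1H-pyrrol-3-yl is not needed for a low number in this series. Nothing available here says which part of the exchange accounts for the step.

The exchange alters the ring size, the hydrogen-bond donor and the methoxy group all at once, so this single pair cannot separate their contributions. An unsubstituted phenyl ring at the same carbon would isolate the part played by the methoxy group, while a 4-hydroxyphenyl or 4-aminophenyl group would show how the ring behaves when it again carries a hydrogen-bond donor.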